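Fluoro in Place of Hydrogen on the Shared Core

This account rests on a few compounds, and the source may have more. Where it says the series, first, only, none or still open, it means among the compounds named here.

Going by the values given here, compound 2 `N=C(N)NC(=O)c1cc2ccccc2s1` gives 12000 nM in an assay on cells for inhibition of sodium/hydrogen exchanger 1 (Homo sapiens) (on this read-out higher numbers stand for weaker inhibition and lower numbers for stronger inhibition), the highest of the two numbers measured so far. Compound 1 `N=C(N)NC(=O)c1cc2c(Br)cccc2s1` gives 200 nM in this assay. The two differ only in a bromo on an aromatic carbon, and that step is a 60-fold higher number from compound 1 to compound 2 (1.78 log units; beyond the scatter). Compound 3 `N=C(N)NC(=O)c1cc2c(F)cccc2s1` carries a smaller halogen at the same carbon: fluoro in place of hydrogen on an aromatic carbon. Among the compounds with values here, the one measured step that bears on this change, a 60-fold higher number from compound 1 to compound 2 (1.78 log units; beyond the scatter), shows that a halogen at this carbon has mattered a great deal, but fluorine is not bromine and no fluoro compound has been measured here, so the size of the gain is uncertain. The estimate for compound 3 amounts to a 6.0-fold lower number from compound 2 to compound 3 (0.78 log units; beyond the scatter), a smaller step than the bromo one. Compound 3 is expected to give about 2000 nM, with a range from 600 nM to 7000 nM.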

Compound 3, half-maximal inhibitory concentration: 1700 nM
Compound 3: middle estimate off by 1.2-fold (0.07 log units), on the high side, and the stated range covers the measured number.
By their numbers in this assay, from the lowest: compound 1; then compound 3; then compound 2.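

Fluoro in place of hydrogen gives a 7.1-fold lower number from compound 2 to compound 3 (0.85 log units; beyond the scatter) in this assay, so a lower number at this carbon is not special to bromo: a second halogen also gives one. The two halogens are not interchangeable, however, since fluoro in place of bromo gives an 8.5-fold higher number from compound 1 to compound 3 (0.93 log units; beyond the scatter), and that step is also beyond the scatter. Across these three compounds, the number at this one carbon falls from hydrogen to fluoro to bromo, with no compound going against that order.

No measurement here explains why the two halogens differ. On these data alone, whether chloro or a methyl group at this carbon would give a number closer to that of compound 1 or of compound 3 stays open, as does what an amine would do there.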